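The compounds below may be only part of what the source reports. "The series", "measured", "known", "first", "only" and "open" are said of these compounds alone.

Three compounds share a core and differ only in the group on an oxygen on a saturated carbon. In an ADME assay on PBMC cells (Homo sapiens) for cytotoxicity (a higher number here means that more compound is tolerated, a lower number that less compound is tolerated), compound 3 `CC(CCNC(=O)c1c(Cl)cncc1Cl)N1CCC(C(Oc2cccc(Cl)n2)c2ccc(C(F)(F)F)cc2)CC1` gives > 32500 nM, which is a limit and not a number. Compound 1 `CC(CCNC(=O)c1c(Cl)cncc1Cl)N1CCC(C(Oc2cccc(C(=O)O)n2)c2ccc(C(F)(F)F)cc2)CC1` gives 28700 nM and compound 2 `CC(CCNC(=O)c1c(Cl)cncc1Cl)N1CCC(C(Oc2ccccc2)c2ccc(C(F)(F)F)cc2)CC1` gives 6800 nM. The step of an at least 1.1-fold higher number from compound 1 to compound 3 (0.05 log units; that floor lies within the scatter) does not separate the first pair, so compound 3 is best read as sitting with compound 1 at the tolerated end of this small set.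

Compound 4 `COC(=O)c1cccc(OC(c2ccc(C(F)(F)F)cc2)C2CCN(C(C)CCNC(=O)c3c(Cl)cncc3Cl)CC2)c1` has not been measured yet. Its change is 3-(methoxycarbonyl)phenyl in place of 6-chloropyridin-2-yl on an oxygen on a saturated carbon, that is, 3-(methoxycarbonyl)phenyl in place of 6-chloropyridin-2-yl. The entering group has one six-membered aromatic ring of carbon only, as the phenyl of compound 2 does. The closest guide is therefore an at least 4.7-fold higher number from compound 2 to compound 3 (0.67 log units; beyond the scatter), read backwards, and the similar a 4.2-fold lower number from compound 1 to compound 2 (0.63 log units; beyond the scatter) points the same way. Among the compounds with values here, no measured step covers the methoxycarbonyl group itself, which leaves the expectation loose. A modest fall is expected, with the estimated move being an at least 2.7-fold lower number from compound 3 to compound 4 (0.43 log units; beyond the scatter). For compound 4 the estimated value is 12000 nM, with an expected range from 5000 nM to 30000 nM.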

Compound 4, half-maximal cytotoxic concentration: 15200 nM
Compound 4: middle estimate off by 1.3-fold (0.10 log units), on the low side, and the stated range covers the measured number.
By their numbers in this assay, from the lowest: compound 2; then compounds 4 and 1 (each within the scatter of the next). At a limit, above all of these: compound 3.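

In this assay, the methoxycarbonyl group is the first group shown on the carbon-only ring, and putting it in place of hydrogen gives a 2.2-fold higher number from compound 2 to compound 4 (0.35 log units; beyond the scatter). So at this position, a pyridine ring is not needed for a number higher than that of the plain phenyl in compound 2. The comparison with the chlorinated pyridine gives an at least 2.1-fold lower number from compound 3 to compound 4 (0.33 log units; beyond the scatter), but this size is only a floor, because compound 3 stands at a limit and not at a number: the limit of > 32500 nM in this assay, at which 1 of the 4 values shown sits. The comparison with the carboxy-bearing pyridine gives a 1.9-fold lower number from compound 1 to compound 4 (0.28 log units; within the scatter), so 3-(methoxycarbonyl)phenyl and 6-carboxypyridin-2-yl cannot be told apart in this assay.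

On these data alone, compound 3 and compound 4 differ in both the ring and the group it carries, so the share of each in their step stays open; a chloro group on the phenyl ring, or a methoxycarbonyl group on the pyridine ring, would help to separate the two. As far as these compounds go, it also remains open whether a carboxylic acid, an amide or an amine on the phenyl ring would give a number like that of the ester in compound 4.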